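Cyclopentyl to furan-2-yl on the shared core

The compounds below may be only part of what the source reports. "The series", "measured", "known", "first", "only" and "open" are said of these compounds alone.

Measured compounds:
compound 1 `Cc1ccc(C(/N=C2\CCCCCN2)C2CC2)c(C)c1` gives 56%
compound 2 `c1ccc(C(/N=C2\CCCCCN2)C2CCCC2)cc1` gives 46%

In a functional assay on the whole organism (plasma, strain Sprague-Dawley) with Rattus norvegicus as the target, with a stated time of 2 h, at a dose of 100 mg/kg by the oral route (a higher number here means a stronger effect of the compound at the dose given, a lower number a weaker effect), compound 2 sits within the usual scatter of compound 1; the two numbers cannot be told apart. Compound 3 `c1ccc(C(/N=C2\CCCCCN2)c2ccco2)cc1` is not yet measured. It differs from compound 2 in one place: furan-2-yl in place of cyclopentyl on a saturated chain carbon bound to an aromatic carbon and a double-bonded nitrogen. No step between measured compounds is available for this change, so nothing shown supports a shift beyond the scatter in either direction; a step of that size from compound 2 to compound 3 in this assay is what is expected, a number 1 percentage points lower from compound 2 to compound 3 (within the scatter). For compound 3 the expected value is 45%, estimated between 20% and 70%.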

Compound 3, a percentage reported as inhibition, in the whole organism at one dose (the size of the read-out at that dose, not a potency): 52%
Compound 3: the middle estimate sits 7 percentage points below what was measured; low and high end bracket the measured number.
By their numbers in this assay, from the lowest: compounds 2, 3 and 1 (each within the scatter of the next).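

Furan-2-yl in place of cyclopentyl on a saturated chain carbon bound to an aromatic carbon and a double-bonded nitrogen gives a number 6 percentage points higher from compound 2 to compound 3 (within the scatter) in this assay. This position therefore accepts a five-membered aromatic ring with one oxygen and one hydrogen-bond acceptor as well as a five-membered ring of carbon only, with no difference that can be told from the scatter. No measurement of any property of these compounds accompanies this result.

As far as these compounds go, whether an amine or a longer chain on this carbon would move the read-out beyond the scatter remains open.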